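Swapping a Ring on the Thiocarbonyl Carbon

The source may hold more compounds than are shown below. What is called first, only, known or untested is meant among the compounds shown, and "the series" means these compounds.

Compound 1 `N/C(=N\NC(=S)N1CCCC1)c1ccc(F)cn1`: 57.9%
Compound 2 `N/C(=N\NC(=S)N1CCSCC1)c1ccccn1`: 34%

In a functional assay on A-375 cells (Homo sapiens) for cytotoxicity, read by MTT assay, with a stated time of 72 h, tested at 1 uM (a higher number here means more inhibition of growth at the concentration tested, a lower number less inhibition of growth), compound 1 gives 57.9%, the higher of the two numbers measured. Compound 2 gives 34% in this assay, a gap beyond the usual scatter. Compound 3 `N/C(=N\NC(=S)N1CCOCC1)c1ccc(F)cn1` has not been measured yet. It differs from compound 1 by morpholin-4-yl in place of pyrrolidin-1-yl on a thiocarbonyl carbon. Going by the values given here, no measured pair shows this exact change, so the direction rests on the two numbers alone. A downward step in this assay is expected, estimated as a number 12.9 percentage points lower from compound 1 to compound 3 (beyond the scatter), possibly beyond the scatter. Compound 3 is expected to give 45%, within a range from 25% to 65%.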

Compound 3, percent growth inhibition at one concentration: 44.5%
Beside the measured number, compound 3's estimate is 0.5 percentage points above it, and the stated range covers the measured number.
By their numbers in this assay, from the lowest: compound 2; then compound 3; then compound 1.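

In this assay, going by these compounds alone, morpholin-4-yl in place of pyrrolidin-1-yl on a thiocarbonyl carbon gives a number 13.4 percentage points lower from compound 1 to compound 3 (beyond the scatter) with the rest of the molecule unchanged, the first direct reading of this change. This position therefore responds to the ring placed on it, and morpholin-4-yl gives the lower growth inhibition of the two. Nothing at hand explains this step.

On these data alone, the ring size and the added oxygen change together in this pair, so their shares remain open. Piperidin-1-yl on the same carbon could separate them.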